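Chain-extended alkynyl pyrimidinediones: antiproliferative series notes

The source may report more compounds than this note shows. Statements on the series, on what has been measured and on what is new or still open speak of the compounds shown alone.

Measured compounds in a functional assay on MCF7 cells (Homo sapiens) for antiproliferative activity, read by MTT assay, with a stated time of 72 h; a higher number here means a weaker inhibitor, a lower number a stronger inhibitor:
- compound 1, `O=c1[nH]c(=O)n(CCC(CO)CO)cc1C#Cc1ccc(Br)cc1`, 46000 nM
- compound 2, `O=c1[nH]c(=O)n(CCC(CO)CO)cc1C#CCc1ccccc1`; its value is a limit of this assay, > 100000 nM (the limit of > 100000 nM in this assay, at which 1 of the 3 values shown sits)
- compound 3, `CCCCCC#Cc1cn(CCC(CO)CO)c(=O)[nH]c1=O`, 37800 nM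

Compound 3 gives the lowest number of the two that are numbers, though its step from compound 1, a 1.2-fold lower number from compound 1 to compound 3 (0.09 log units; within the scatter), sits within the scatter. Compound 2 sits at the limit; the step of an at least 2.6-fold lower number from compound 2 to compound 3 (0.42 log units; beyond the scatter) is beyond the scatter.

Compound 4, `CCCCCCCCC#Cc1cn(CCC(CO)CO)c(=O)[nH]c1=O`, is not yet measured. It differs from compound 3 by propyl in place of hydrogen on a saturated chain carbon, five bonds along the chain from a triple-bonded carbon. Among the compounds with values here, none of the measured steps changes the length of a saturated chain on the triple bond; the step of an at least 2.1-fold higher number from compound 1 to compound 2 (0.33 log units; beyond the scatter) and the other two swap ring for chain instead. Within the data shown here, no measured step therefore bears directly on this change, and nothing beyond the scatter is expected in this assay: the expected step is a 1.3-fold lower number from compound 3 to compound 4 (0.10 log units; within the scatter). Compound 4 is estimated at 30000 nM, in the range 12000 nM to 80000 nM.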

Compound 4, half-maximal inhibitory concentration: 40300 nM
Beside the measured number, compound 4's estimate is 1.3-fold (0.13 log units) below it; measured number inside the range.
By their numbers in this assay, from the lowest: compounds 3, 4 and 1 (each within the scatter of the next). At a limit, above all of these: compound 2.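

Adding propyl at this position, five bonds along the chain from a triple-bonded carbon, gives no difference beyond the scatter in this assay (a 1.1-fold higher number from compound 3 to compound 4 (0.03 log units; within the scatter)). The step of a 1.1-fold lower number from compound 1 to compound 4 (0.06 log units; within the scatter) also stays within the scatter. The step from the limit, (an at least 2.4-fold lower number from compound 2 to compound 4 (0.39 log units; beyond the scatter)), is a bound only: the limit of > 100000 nM in this assay, at which 1 of the 4 values shown sits.

On these data alone, whether a chain longer than that of compound 4, or a chain carrying an amine or a carboxylic acid, gives a number beyond the scatter stays open.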